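Working notes: fluoro in place of methoxy

The compounds below may be only part of what the source reports. "The series", "measured", "known", "first", "only" and "open" are said of these compounds alone.

In a functional assay on KBVIN cells (Homo sapiens) for antiproliferative activity, read by sulforhodamine B assay, with a stated time of 3 days (on this read-out lower numbers stand for an effect already at smaller amounts and higher numbers for an effect only at larger amounts of compound), compound 1 (`CCC1=C(O)c2c(oc(-c3cccc(F)c3)cc2=O)C(CC)(CC)C1=O`) gives 3.09 uM and compound 2 (`CCC1=C(O)c2c(oc(-c3ccccc3OC)cc2=O)C(CC)(CC)C1=O`) gives 3.26 uM. Among the measured compounds shown here, compound 2 therefore stands level with compound 1, and the only measured step, a 1.1-fold higher number from compound 1 to compound 2 (0.02 log units; within the scatter), lies within the scatter. Compound 3 (`CCC1=C(O)c2c(oc(-c3ccccc3F)cc2=O)C(CC)(CC)C1=O`) carries fluoro in place of methoxy on an aromatic carbon, ortho to a large group: fluoro in place of methoxy on an aromatic carbon. That one measured step bears on this change only indirectly, as it also exchanged aryl groups on the shared core. The expected step is a 1.1-fold lower number from compound 2 to compound 3 (0.04 log units; within the scatter), with nothing beyond the scatter anticipated. For compound 3 the estimated value is 3 uM, with an expected range of 1.3 uM to 7 uM.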

Compound 3, concentration for half-maximal effect: 3.93 uM
The estimate for compound 3 lay 1.3-fold (0.12 log units) below the measured number; measured number inside the range.
By their numbers in this assay, from the lowest: compounds 1, 2 and 3 (each within the scatter of the next).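

Fluoro in place of methoxy on an aromatic carbon, ortho to a large group, now has a direct reading in this assay: a 1.2-fold higher number from compound 2 to compound 3 (0.08 log units; within the scatter). The 2-fluorophenyl and 3-fluorophenyl groups also read level, with a 1.3-fold higher number from compound 1 to compound 3 (0.10 log units; within the scatter). No independent data on these compounds accompany these numbers to explain them.

Open, as far as these compounds go, is whether an amine or a carboxylic acid on this aromatic carbon would stay level with these three compounds.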